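The compounds below may be only part of what the source reports. "The series", "measured", "known", "first", "only" and "open" are said of these compounds alone.

Measured compounds:
- compound 1 `CCCCOC(=O)CC1c2cccc(C)c2S(=O)(=O)N1CCCC` — "not determined" (no result reported) in an assay on HEK-Blue hNOD1 cells for antagonist activity at Nucleotide-binding oligomerization domain-containing protein 1 (Homo sapiens), read by reporter gene assay, with stated times of 3 h and 20 h; on this read-out higher numbers stand for weaker inhibition and lower numbers for stronger inhibition
- compound 2 `CCCCOC(=O)CC1c2cccc(C)c2S(=O)(=O)N1C(=O)c1ccc(Cl)cc1` — 2140 nM in this assay

Among the compounds with values here, compound 2 carries the only number in this assay, so it stands alone; no step between measured compounds can be drawn, and the missing result for compound 1 leaves nothing to compare against. Compound 3 `CCCCOC(=O)CC1c2cccc(C)c2S(=O)(=O)N1C(=O)c1ccc(C#N)cc1` differs from compound 2 by cyano in place of chloro on an aromatic carbon. Within the data shown here, no measured pair shows what this exchange does, so nothing beyond the scatter of repeated measurements can be claimed for it. The expectation is a step of about a 1.2-fold higher number from compound 2 to compound 3 (0.08 log units; within the scatter) from compound 2 to compound 3, which is not beyond the usual scatter. Among the measured compounds shown here, compound 3 is therefore estimated at 2600 nM in this assay, with a range from 900 nM to 7500 nM, the width reflecting that only one measured value, that of compound 2, anchors the estimate.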

Compound 3, half-maximal inhibitory concentration: 3830 nM
Compound 3: the middle estimate sits 1.5-fold (0.17 log units) below what was measured; low and high end bracket the measured number.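

In this assay, cyano in place of chloro, on the aromatic carbon para to a large group, gives a 1.8-fold higher number from compound 2 to compound 3 (0.25 log units; within the scatter). Within the data shown here, this is the first step that can be read, and on this read-out it does not separate 4-cyanophenyl from 4-chlorophenyl, although the entering group counts one hydrogen-bond acceptor and the leaving group none. No supporting measurement bears on this result.

The pair leaves open whether the same place accepts a group of another kind, such as an amine or a carboxylic acid, since chloro and cyano are the only groups shown there. Also open, as far as these compounds go, is what a change elsewhere would do, such as a carboxylic acid in place of the ester on the shared core.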